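The compounds below may be only part of what the source reports. "The series", "measured", "known", "first", "only" and "open" are said of these compounds alone.

Working notes on the series. In a functional assay on A549 cells (Homo sapiens) for antiproliferative activity, read by MTT assay, with a stated time of 24 h (a lower number here means a stronger inhibitor, a higher number a weaker inhibitor), compound 1 `COc1ccc(-c2cc(C(=O)/C=C/c3ccccc3)nc3cc(-c4ccccc4)nn23)cc1OC` gives 18600 nM, compound 2 `COc1ccc(-c2cc(/C=C/C(=O)c3cc(OC)c(OC)c(OC)c3)nc3cc(-c4ccccc4)nn23)cc1OC` gives 7200 nM, and compound 3 `COc1cc(-c2cc(/C=C/C(=O)c3ccccc3)nc3cc(-c4ccccc4)nn23)cc(OC)c1OC` gives 18200 nM. Among these three numbers compound 3 stands second highest: its nearest neighbour is compound 1, whose number is within the scatter of it, and its furthest is compound 2, whose number is lower by a margin beyond the scatter. Nothing in this set separates the two within-scatter compounds, so no order is drawn between compound 1 and compound 3.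

The next compound, compound 4 `COc1ccc(-c2cc(/C=C/C(=O)c3ccccc3)nc3cc(-c4ccccc4)nn23)cc1OC`, is reached from compound 3 by a single change: hydrogen in place of methoxy on an aromatic carbon, which read one bond further out is 3,4,5-trimethoxyphenyl to 3,4-dimethoxyphenyl. Going by the values given here, no measured pair shows this exact change, so the size of its effect is open. The removal of one methoxy is a small change in a region of the molecule where the measured compounds give no guidance, and no step beyond the scatter in this assay is expected in either direction. Compound 4 is therefore estimated at 20000 nM, with a range of 8000 nM to 50000 nM, an expected step of a 1.1-fold higher number from compound 3 to compound 4 (0.04 log units; within the scatter).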

Compound 4, half-maximal inhibitory concentration: 10700 nM
For compound 4 the middle estimate is 1.9-fold (0.27 log units) above the measured one; the range from low to high includes it.
By their numbers in this assay, from the lowest: compounds 2, 4, 3 and 1 (each within the scatter of the next, the first and the last beyond it).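

In this assay, hydrogen in place of methoxy on this aromatic carbon gives a 1.7-fold lower number from compound 3 to compound 4 (0.23 log units; within the scatter), so 3,4,5-trimethoxyphenyl and 3,4-dimethoxyphenyl are not separated at this position. The first single-change readings elsewhere on the shared core are also unresolved: phenyl in place of 3,4,5-trimethoxyphenyl on the carbonyl carbon gives a 1.5-fold higher number from compound 2 to compound 4 (0.17 log units; within the scatter), and 2-benzoylethenyl in place of (2-phenylethenyl)carbonyl gives a 1.7-fold lower number from compound 1 to compound 4 (0.24 log units; within the scatter). No supporting measurement bears on any of these steps.

As far as these compounds go, whether a hydroxyl or an amine on this aromatic carbon, or a longer chain in place of the 2-benzoylethenyl group, would give a step beyond the scatter remains open. Also open, from the compounds shown here alone, is whether these steps would hold in other cell lines.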